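A few compounds are considered here, and "the series" means these few. Any claim that something is new, unique, unknown or untested is made for them only; others in the source may bear on it.

Working notes on the series. In an ADME assay on microsomes from liver (Mus musculus) for metabolic stability, read by LC-MS, using NADPH, with a stated time of 10 min, tested at 0.1 uM (a higher number here means faster removal of the compound, a lower number slower removal), compound 1 (`COc1ccc(F)cc1N1C(=O)CSC1c1cccc(C(=O)NCCCCc2ccccc2)c1`) gives 2250 mL.min-1.g-1 and compound 2 (`C#Cc1cc(C(=O)NCCCCc2ccccc2)cc(C2SCC(=O)N2c2ccccc2OC)c1`) gives 2490 mL.min-1.g-1. Going by the values given here, these two numbers lie within the scatter of each other, so compound 1 stands level with the only other measured compound.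

Compound 3 (`C#Cc1cccc(N2C(=O)CSC2c2cccc(C(=O)NCCCCc3ccccc3)c2)c1`) is still to be measured. It carries 3-ethynylphenyl in place of 5-fluoro-2-methoxyphenyl on an amide-type nitrogen in a ring, the rest of the structure being that of compound 1: 3-ethynylphenyl in place of 5-fluoro-2-methoxyphenyl on an amide-type nitrogen in a ring.

Among the compounds with values here, no measured pair differs in one place only, so the effect of this exchange has not been observed directly. The expectation rests on two structurally different compounds giving close numbers, compound 1 at 2250 mL.min-1.g-1 and compound 2 at 2490 mL.min-1.g-1. With so little data, the range is kept wide on both sides.

In this assay, no change beyond the scatter is expected, and the estimated step is a 1.0-fold higher number from compound 1 to compound 3 (0.01 log units; within the scatter). For compound 3, the expected value is 2300 mL.min-1.g-1, with an estimated range of 1200 mL.min-1.g-1 to 4000 mL.min-1.g-1.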

Compound 3, intrinsic clearance in microsomes: 1900 mL.min-1.g-1
The estimate for compound 3 lay 1.2-fold (0.08 log units) above the measured number, and the stated range covers the measured number.
By their numbers in this assay, from the lowest: compounds 3, 1 and 2 (each within the scatter of the next).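

In this assay the exchange to 3-ethynylphenyl in place of 5-fluoro-2-methoxyphenyl on the amide-type nitrogen in the ring gives a 1.2-fold lower number from compound 1 to compound 3 (0.07 log units; within the scatter) as a direct reading at this position. The earlier pair differed in more than one place, whereas this step isolates a single exchange on the shared core. At this position, losing the methoxy and fluoro substituents and gaining a triple bond outside aromatic rings leaves the intrinsic clearance in microsomes level within the scatter, for this one pair only. Nothing measured here bears on what lies behind this result.

As far as these compounds go, whether an amine or a carboxylic acid on the aromatic ring at this position would move the number beyond the scatter remains open. Also open, from the compounds shown here alone, is what the methoxy, fluoro and ethynyl groups each contribute on their own, as this step exchanges all of them at once.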